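Series notes: oxadiazole sulfonamides at the EP1 receptor

The compounds below may be only part of what the source reports. "The series", "measured", "known", "first", "only" and "open" are said of these compounds alone.

Measured so far:
compound 1 `COc1ccc(Cc2nnc(CN(c3cccc(Cl)c3Cl)S(=O)(=O)c3ccc(C)cc3)o2)cc1` — 7.94 nM
compound 2 `Cc1ccc(S(=O)(=O)N(Cc2nnc(Cc3ccc(C(F)(F)F)cc3)o2)c2cccc(Cl)c2C)cc1` — 50.1 nM

In an assay on CHO cells for displacement of a labelled ligand from prostaglandin E2 receptor EP1 subtype (Homo sapiens) (on this read-out higher numbers stand for weaker inhibition and lower numbers for stronger inhibition), compound 2 gives 50.1 nM, the higher of the two numbers recorded. Compound 1 gives 7.94 nM in this assay, a gap that lies beyond the scatter; the two structures differ in more than one place, so the gap cannot be assigned to any single change.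

Compound 3 `COc1ccc(Nc2nnc(CN(c3cccc(Cl)c3C)S(=O)(=O)c3ccc(C)cc3)o2)cc1` is not yet measured. It differs from compound 2 as follows: (4-methoxyphenyl)amino in place of 4-(trifluoromethyl)benzyl on an aromatic carbon. Among the measured compounds shown here, no pair of measured compounds isolates this change, so there is no direct precedent. Compound 1, which carries a methoxy-bearing ring at the same position of the core, sits lower than compound 2, but its other differences leave that reading open.

For compound 3 a modest move toward lower numbers in this assay is expected, as the step of a 2.0-fold lower number from compound 2 to compound 3 (0.30 log units; within the scatter), with a wide range. The estimate for compound 3 in this assay is 25 nM, between 5 nM and 125 nM.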

Compound 3, half-maximal inhibitory concentration: 31.6 nM
Beside the measured number, compound 3's estimate is 1.3-fold (0.10 log units) below it; low and high end bracket the measured number.
By their numbers in this assay, from the lowest: compound 1; then compounds 3 and 2 (each within the scatter of the next).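

In this assay, putting (4-methoxyphenyl)amino in place of 4-(trifluoromethyl)benzyl on the aromatic carbon of the five-membered ring gives a 1.6-fold lower number from compound 2 to compound 3 (0.20 log units; within the scatter), so the two groups cannot be told apart on this read-out. Among the compounds shown here, this is the first comparison that isolates this position, and it shows that the position tolerates a substantial exchange: the entering group carries 1 hydrogen-bond donor and 2 hydrogen-bond acceptors where the leaving group has 0 of each, and the linking atom to the six-membered ring changes, yet the number stays within the scatter. No supporting measurement is available to account for this result.

Going by these compounds, compound 1 differs from compound 2 and from compound 3 in more than one place, so its value still cannot be assigned to its 4-methoxybenzyl group or to its dichlorinated ring, and whether (4-methoxyphenyl)amino would behave the same way beside that dichlorinated ring remains open. Also open, on these data alone, is whether the position would tolerate a carboxylic acid, a morpholine or a longer chain in place of these ring-bearing groups.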